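Swapping Octyl for Nitrophenyl on a Weak Triazole Series

The source may hold more compounds than are shown below. What is called first, only, known or untested is meant among the compounds shown, and "the series" means these compounds.

Compound 1 `CCCCCCCCn1cc(COC2(C(F)(F)F)Oc3ccccc3C=C2C(=O)OCC)nn1` is known only as a limit in a functional assay on A549 cells (Homo sapiens) for inhibition, read by MTT assay, with a stated time of 24 h; a higher number here means a weaker inhibitor, a lower number a stronger inhibitor: compound 1 gives > 150000 nM, which is a limit of the assay and not a number. Its two companions are no more readable. Compound 2 `O=C(O)C1=Cc2ccccc2OC1(OCc1cc(-c2ccc3ccccc3c2)no1)C(F)(F)F` gives > 150000 nM, a limit. Compound 3 `O=C(O)C1=Cc2ccccc2OC1(OCc1cc(-c2ccc(F)cc2F)no1)C(F)(F)F` gives > 150000 nM, also a limit. Going by the values given here, the only measured step, a step that the two limits leave unreadable from compound 2 to compound 3, is unreadable because of the limit of > 150000 nM in this assay, at which 3 of the 3 values shown sit. The change from compound 1 to compound 4 `CCOC(=O)C1=Cc2ccccc2OC1(OCc1cn(-c2ccc([N+](=O)[O-])cc2)nn1)C(F)(F)F` is 4-nitrophenyl in place of octyl on an aromatic nitrogen. Among the compounds with values here, no measured step involves this change, so nothing points toward either direction. With every value a limit, compound 4 is expected to stay near that limit, and a number no higher from compound 1 to compound 4 (the limit leaves the size open) is estimated as no step beyond the scatter. The estimate for compound 4 is 150000 nM, in the range 40000 nM to 400000 nM.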

Compound 4, half-maximal inhibitory concentration: > 150000 nM
Compound 4 was reported as a limit; the forecaster's own chance of this, stated with the estimate: 75%; the middle value lies on the limit itself.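

Compound 4 gives > 150000 nM in this assay, which is a limit and not a number. The step from compound 1 to compound 4 therefore cannot be read, because of this: the limit of > 150000 nM in this assay, at which 4 of the 4 values shown sit. The compounds shown leave open how octyl and 4-nitrophenyl compare, and how strong an inhibitor any of the four is.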